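Cytotoxicity notes on three anilides and one proposed analogue

The source may hold more compounds than are shown below. What is called first, only, known or untested is meant among the compounds shown, and "the series" means these compounds.

Values in an ADME assay on HepG2 cells (Homo sapiens) for cytotoxicity, read by trypan blue exclusion, with a stated time of 48 h, in the presence of a further agent that is not named here; on this read-out lower numbers stand for higher toxicity in this test and higher numbers for lower toxicity in this test:
compound 1 `COc1cccc(NC(=O)COc2cc(C)nc3ccc(OC)cc23)c1`: 24700 nM
compound 2 `COc1ccc2nc(C)cc(OCC(=O)Nc3cccc(Br)c3)c2c1`: > 125000 nM (a limit)
compound 3 `COc1ccc2nc(C)cc(OCC(=O)Nc3ccc(Br)cc3)c2c1`: > 125000 nM (a limit)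

Compound 3 gives only a limit in this assay, namely > 125000 nM. Compound 2 likewise gives only a limit, > 125000 nM. Both sit at the limit of > 125000 nM in this assay, at which 2 of the 3 values shown sit. From compound 1 the steps of an at least 5.0-fold higher number from compound 1 to compound 2 (0.70 log units; beyond the scatter) and an at least 5.0-fold higher number from compound 1 to compound 3 (0.70 log units; beyond the scatter) run towards lower toxicity, while a step that the two limits leave unreadable from compound 2 to compound 3 cannot be sized. Compound 4 `COc1ccc2nc(C)cc(OCC(=O)Nc3ccc(-c4ccccc4)cc3)c2c1` carries the change (phenyl in place of bromo on an aromatic carbon). For the measured compounds named here, no measured step tests this exchange; the two steps from compound 1 show only that the aryl on the amide-type nitrogen can be varied without raising toxicity. Compound 4 is therefore expected to stay near the limit, estimated at 125000 nM (range 40000 nM to 300000 nM). The expected step is a number no higher from compound 3 to compound 4 (the limit leaves the size open).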

Compound 4, half-maximal cytotoxic concentration: > 126000 nM
Compound 4 ended at the assay's limit; the forecaster's own chance of this, stated with the estimate: 60%; at least 1.0-fold (0.00 log units) between middle value and limit.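

In this assay compound 3 and compound 4 both give only limits, and the step between them, phenyl in place of bromo, cannot be read. The compounds shown leave open whether this exchange changes toxicity at all.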